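Alpha-carbon substituent series: methyl to propyl on the shared core

The source may report more compounds than this note shows. Statements on the series, on what has been measured and on what is new or still open speak of the compounds shown alone.

Compound 1 `CCN(CC)CCCN(C(=O)c1ccc(-c2ccccc2)[nH]1)C(C(=O)NC1CCCCC1)c1ccc(F)cc1` gives 1290 nM in an assay on isolated protein for binding affinity to growth hormone secretagogue receptor type 1 (Homo sapiens); on this read-out lower numbers stand for stronger inhibition and higher numbers for weaker inhibition. Compound 2 `CCN(CC)CCCN(C(=O)c1ccc(-c2ccccc2)[nH]1)C(C(=O)NC1CCCCC1)c1ccc(O)cc1` gives 1320 nM, and compound 3 `CCN(CC)CCCN(C(=O)c1ccc(-c2ccccc2)[nH]1)C(C)C(=O)NC1CCCCC1` gives 1920 nM, the highest of the three numbers, though its steps to both others stay within the scatter. The three compounds differ only at the saturated chain carbon bound to the amide-type nitrogen and the carbonyl carbon: the step of a 1.0-fold higher number from compound 1 to compound 2 (0.01 log units; within the scatter) was flat, and the replacement of an aryl group by methyl in a 1.5-fold higher number from compound 1 to compound 3 (0.17 log units; within the scatter) and a 1.5-fold higher number from compound 2 to compound 3 (0.16 log units; within the scatter) moved the number by small amounts only. Compound 4 `CCCC(C(=O)NC1CCCCC1)N(CCCN(CC)CC)C(=O)c1ccc(-c2ccccc2)[nH]1` carries ethyl in place of hydrogen on a saturated chain carbon, two bonds along the chain from an amide-type nitrogen and a carbonyl carbon. The measured steps bear directly on this carbon. Neither the replacement of 4-fluorophenyl by methyl nor the replacement of 4-hydroxyphenyl by methyl moved this assay beyond the scatter. An ethyl extension is therefore expected to give no step beyond the scatter either, in either direction. The expected step is a 1.1-fold lower number from compound 3 to compound 4 (0.05 log units; within the scatter). Compound 4 is expected at about 1700 nM, with a range of 700 nM to 4000 nM.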

Compound 4, inhibition constant: 870 nM
For compound 4 the middle estimate is 2.0-fold (0.29 log units) above the measured one; measured number inside the range.
By their numbers in this assay, from the lowest: compounds 4, 1, 2 and 3 (each within the scatter of the next, the first and the last beyond it).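

Within the data shown here, at the saturated chain carbon bound to the amide-type nitrogen and the carbonyl carbon, the change from methyl to propyl gives the first step in this assay that lies beyond the scatter, though only a modest one (a 2.2-fold lower number from compound 3 to compound 4 (0.34 log units; beyond the scatter)). Compound 4 stays within the scatter of both aryl-bearing compounds (a 1.5-fold lower number from compound 2 to compound 4 (0.18 log units; within the scatter); a 1.5-fold lower number from compound 1 to compound 4 (0.17 log units; within the scatter)), so propyl is not separated from 4-hydroxyphenyl or 4-fluorophenyl, and only the methyl compound is set apart from it. No supporting data are available to explain the step from methyl to propyl.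

A longer chain such as butyl or a branched chain such as isopropyl would show whether the gain over methyl continues with chain size. As far as these compounds go, how an amine or a carboxylic acid on the chain would compare with propyl also remains open.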